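Epimer at the carbinol stereocentre in the urea series

A few compounds are considered here, and "the series" means these few. Any claim that something is new, unique, unknown or untested is made for them only; others in the source may bear on it.

Two compounds have results in a functional assay for inhibition, with Homo sapiens as the target; on this read-out higher numbers stand for weaker inhibition and lower numbers for stronger inhibition. Compound 1 `CC(C)N1CC(c2ccc(Cl)c(Cl)c2)CN(c2ccc(CNC(=O)C(C)(C)C)cc2)C1=O` is reported only as a limit of the assay, > 10000 nM, and (the limit of > 10000 nM in this assay, at which 1 of the 2 values shown sits). Within the data shown here, compound 2 `CC(C)(C)C(=O)NCc1ccc(NC(=O)N2CCCC[C@H]2[C@@H](O)c2ccc(Cl)c(Cl)c2)cc1` gives 4300 nM in this assay, which is the only measured number in the set, so compound 2 stands alone as the compound with a figure. Compound 3 `CC(C)(C)C(=O)NCc1ccc(NC(=O)N2CCCC[C@H]2[C@H](O)c2ccc(Cl)c(Cl)c2)cc1` is not yet measured. It differs from compound 2 in one way: the two compounds have the same atoms and bonds and differ only in configuration as drawn: 1 of 2 stereo elements differ; a stereocentre at a saturated chain carbon is drawn S in compound 2 and R in compound 3. Among the measured compounds shown here, no step between measured compounds is available, so the size and direction of the change on inverting the drawn configuration at the saturated chain carbon is unknown; a step beyond the scatter in either direction is possible, as is none. Compound 3 is expected to give about 5000 nM in this assay, with a range from 1500 nM to 20000 nM. The expected step of a 1.2-fold higher number from compound 2 to compound 3 (0.07 log units; within the scatter) is therefore estimated as modest, with wide uncertainty around it.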

Compound 3, half-maximal inhibitory concentration: > 10000 nM
Compound 3 was reported as a limit; the forecaster's own chance of this, stated with the estimate: 35%; middle value at least 2.0-fold (0.30 log units) from the limit.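

In this assay, among these compounds, inverting the carbinol stereocentre gives an at least 2.3-fold higher number from compound 2 to compound 3 (0.36 log units; beyond the scatter) and this is the only readable step, so the drawn configuration at this saturated chain carbon counts for the urea pair. Compound 3 gives > 10000 nM and this is a limit of the assay, so the step has a direction and a minimum size but no end point. Nothing else separates the pair, so the step belongs to this one stereocentre: the fact that compounds 2 and 3 differ only in the configuration as drawn.

The compounds shown leave open how far the step runs past the limit, and whether the other stereocentre carries a step of its own. They also leave open how an amine or a methyl ether in place of the carbinol hydroxyl would read at this position.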